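A few compounds are considered here, and "the series" means these few. Any claim that something is new, unique, unknown or untested is made for them only; others in the source may bear on it.

Two thioureas that share one core have been tested in an ADME assay on Vero 76 cells (Chlorocebus sabaeus) for cytotoxicity, read by crystal violet staining, with a stated time of 96 h; on this read-out higher numbers stand for lower toxicity in this test and lower numbers for higher toxicity in this test. Compound 1, `Fc1ccccc1NC(=S)Nc1cccc(C(F)(F)F)c1`, gives 64000 nM. Compound 2, `CCOC(=O)c1ccc(NC(=S)Nc2cccc(C(F)(F)F)c2)cc1`, gives 71000 nM, and the gap between compound 2 and compound 1 lies within the usual scatter of such measurements. Compound 3, `Fc1ccc(NC(=S)Nc2cccc(C(F)(F)F)c2)cc1`, differs from compound 2 by fluoro in place of ethoxycarbonyl on an aromatic carbon. Within the data shown here, with no measured step of this kind to lean on, and with compound 2 sitting close to compound 1, which also carries a fluoro group and gives 64000 nM, the step of a 1.1-fold lower number from compound 2 to compound 3 (0.04 log units; within the scatter) is expected to stay within the scatter. Compound 3 is therefore estimated to give about 65000 nM, likely between 35000 nM and 130000 nM.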

Compound 3, half-maximal cytotoxic concentration: 40000 nM
Beside the measured number, compound 3's estimate is 1.6-fold (0.21 log units) above it, within the range that was stated.
By their numbers in this assay, from the lowest: compounds 3, 1 and 2 (each within the scatter of the next).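

In this assay, fluoro in place of ethoxycarbonyl, para to a large group, gives a 1.8-fold lower number from compound 2 to compound 3 (0.25 log units; within the scatter), so a one-atom group and a five-atom ester group cannot be told apart at this position. Moving the fluorine, with 4-fluorophenyl in place of 2-fluorophenyl on an amide-type nitrogen, gives a 1.6-fold lower number from compound 1 to compound 3 (0.20 log units; within the scatter), so that change cannot be told apart from no change either. Nothing available here offers an explanation for these numbers.

Still open, as far as these compounds go, is whether an amine, a carboxylic acid or a longer chain at this position would produce a step beyond the scatter.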